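From Methoxy to a Carbamoyl Chain on Compound 1

This account rests on a few compounds, and the source may have more. Where it says the series, first, only, none or still open, it means among the compounds named here.

- compound 1 `COc1ccc2c(c1)CC(c1nc3ccc(-c4ccnc(N)n4)cc3[nH]1)CO2` - 0.467 h
- compound 2 `Nc1nccc(-c2ccc3nc(C4COc5c(cccc5C(=O)NC5CC5)C4)[nH]c3c2)n1` - 1.32 h

In an in vitro ADME assay on microsomes from liver (Homo sapiens) for metabolic stability (a higher number here means that the compound lasts longer, a lower number that the compound disappears faster), compound 1 gives 0.467 h and stands lowest of the two measured compounds. Compound 2 gives 1.32 h and lies above it by more than the usual scatter, but the two differ in more than one place, so no clean single change connects them.

The next structure is compound 3 `CN(C)CCCNC(=O)c1ccc2c(c1)CC(c1nc3ccc(-c4ccnc(N)n4)cc3[nH]1)CO2`, which carries (3-(dimethylamino)propyl)carbamoyl in place of methoxy on an aromatic carbon and leaves the rest of compound 1 unchanged. For the measured compounds named here, no measured pair shows this change directly, so any forecast rests on thin evidence. Compound 2 also carries an amide, though with a different substituent, and a modest rise is expected because compound 2 gives 1.32 h in this assay as the only amide measured so far. The estimated step of a 1.7-fold higher number from compound 1 to compound 3 (0.23 log units; within the scatter) is upward but is expected to stay within the scatter. Compound 3 is thus estimated at 0.8 h with an expected range from 0.3 h to 2 h when it is measured.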

Compound 3, half-life: 1.67 h
Compound 3: the middle estimate sits 2.1-fold (0.32 log units) below what was measured; the range from low to high includes it.
By their numbers in this assay, from the lowest: compound 1; then compounds 2 and 3 (each within the scatter of the next).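

In this assay, for the compounds shown here, putting (3-(dimethylamino)propyl)carbamoyl in place of methoxy gives a 3.6-fold higher number from compound 1 to compound 3 (0.55 log units; beyond the scatter), the first step that can be read at a single place in the molecule. It shows that this aromatic carbon, on the six-membered aromatic ring of carbon only, can carry a chain of 9 heavy atoms instead of a group of 2, with a hydrogen-bond donor added, and that the half-life rises rather than falls. Nothing measured here explains the rise, so the step stands as an observation about this one change on the core of compound 1.

The compounds shown do not separate the part played by the amide from that of the dimethylamino group, a question that a plain primary amide, a simple N-methyl amide or a carboxylic acid on the same carbon would bear on. Nor do they show how the half-life depends on the chain, which a shorter or longer chain ending in the same amine, or one ending in a morpholine, would help to settle.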